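The compounds below may be only part of what the source reports. "The series", "measured", "known", "first", "only" and "open" are said of these compounds alone.

In a functional assay on HCT-116 cells (Homo sapiens) for cytotoxicity, read by sulforhodamine B assay, with a stated time of 48 h (on this read-out higher numbers stand for weaker inhibition and lower numbers for stronger inhibition), compound 1 (`O=C(Nc1n[nH]c2c1CN(C(=O)c1ccccc1)C2)c1ccc(F)cc1`) gives 3190 nM and compound 2 (`CC(=O)n1nc(NC(=O)c2ccccc2)c2c1CN(C(=O)C1CCC(C)CC1)C2`) gives 12200 nM as the higher of the two numbers, a gap beyond the scatter. Compound 3 (`CC(=O)n1nc(NC(=O)c2ccccc2)c2c1CN(C(=O)c1cccc(F)c1)C2`) carries 3-fluorophenyl in place of 4-methylcyclohexyl on a carbonyl carbon. Within the data shown here, no measured step isolates this change. Among the measured compounds shown here, compound 1 (3190 nM) offers the only comparison, so a modest step toward lower numbers is expected in this assay and it may stay close to the scatter. The estimated move is a 2.0-fold lower number from compound 2 to compound 3 (0.31 log units; beyond the scatter) on this basis. Compound 3 is expected at 6000 nM (estimated range 2000 nM to 16000 nM).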

Compound 3, half-maximal inhibitory concentration: 21900 nM
Compound 3: middle estimate off by 3.7-fold (0.56 log units), on the low side, outside the stated range (above it).
By their numbers in this assay, from the lowest: compound 1; then compounds 2 and 3 (each within the scatter of the next).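

In this assay, among these compounds, the first step at this position, a 1.8-fold higher number from compound 2 to compound 3 (0.25 log units; within the scatter), shows that 3-fluorophenyl in place of 4-methylcyclohexyl on a carbonyl carbon does not separate the two compounds. An aromatic ring bearing fluorine and a non-aromatic ring bearing methyl, each with the same count of heavy atoms, therefore read alike here. No available evidence bears on this result. The compounds shown leave open whether an amine, a carboxylic acid or a longer alkyl chain at this place would give a step beyond the scatter.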